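Swapping the arylidene aryl group in a fused pyrazoline series

The source may hold more compounds than are shown below. What is called first, only, known or untested is meant among the compounds shown, and "the series" means these compounds.

Measured compounds:
compound 1 `COc1ccc(/C=C2\CCCC3C2=NN(C2=NC(=O)/C(=C/c4ccc(OC)c(OC)c4)S2)C3c2ccc(OC)cc2)cc1`: 75.8%
compound 2 `CCN1C/C(=C\c2ccc(OC)cc2)C2=NN(c3nc(-c4ccc(Cl)cc4)cs3)C(c3ccc(OC)cc3)C2C1`: 100%
compound 3 `COc1ccc(/C=C/C2=NN(C(N)=S)C(c3ccc(OC)cc3)C2)cc1`: 98%

In a functional assay on Ehrlich cells (Mus musculus) for cytotoxicity, read by trypan blue exclusion, with a stated time of 24 h, tested at 100 uM (a higher number here means a stronger effect of the compound at the concentration tested, a lower number a weaker effect), compound 1 gives 75.8%, the lowest of the three numbers. Compound 3 gives 98% and compound 2 gives 100%; both lie beyond the scatter above compound 1, with compound 3 the nearer and compound 2 the further.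

Compound 4 `COc1ccc(/C=C2\CCCC3C2=NN(C2=NC(=O)/C(=C/c4ccc(Cl)cc4)S2)C3c2ccc(OC)cc2)cc1` has not yet been measured in this assay. It differs from compound 1 in one place: 4-chlorophenyl in place of 3,4-dimethoxyphenyl on a double-bonded chain carbon bound to a double-bonded ring carbon. Among the measured compounds shown here, no step between two measured compounds matches this change, so the comparison rests on the three numbers alone. A modest step upward is expected, a number 9.2 percentage points higher from compound 1 to compound 4 (within the scatter), which may not exceed the scatter. Compound 4 is therefore expected to give about 85%, within a range of 65% to 100%.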

Compound 4, a percentage reported as activity, at one concentration (the size of the read-out at that concentration, not a potency) in the Ehrlich assay: 84%
Compound 4: middle estimate off by 1 percentage points, on the high side, within the range that was stated.
By their numbers in the Ehrlich assay, from the lowest: compounds 1 and 4 (each within the scatter of the next); then compounds 3 and 2 (each within the scatter of the next).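

In the Ehrlich assay the swap at this position gives a number 8.2 percentage points higher from compound 1 to compound 4 (within the scatter), so 4-chlorophenyl and 3,4-dimethoxyphenyl on a double-bonded chain carbon bound to a double-bonded ring carbon cannot be told apart. In a physicochemical assay for inhibition, read by colorimetric assay, tested at 1 mg/mL (a lower number here means less inhibition, a higher number more inhibition at the concentration tested (going by the name of the read-out)), compound 1 gives 19.1% and compound 4 gives 25.7% in a step that also cannot be told apart (a number 6.6 percentage points higher from compound 1 to compound 4 (within the scatter)). Nothing available explains either result.

Going by these compounds, whether an amine or a carboxylic acid in place of the 4-chlorophenyl group would move either number beyond the scatter remains open. So does whether the same swap would behave alike on the cores of compound 2 or compound 3.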